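Amide versus sulfonamide on the aminoethyl linker

The source may hold more compounds than are shown below. What is called first, only, known or untested is meant among the compounds shown, and "the series" means these compounds.

Compound 3 `O=S(=O)(NCCNc1nccc(-c2c(-c3cccc(F)c3)nc3sccn23)n1)c1ccc(Cl)cc1` gives the highest number of the three measured in a functional assay on A-375 cells (Homo sapiens) for cytotoxicity, read by MTT assay (on this read-out lower numbers stand for stronger inhibition and higher numbers for weaker inhibition), at 18600 nM; compound 2 `O=S(=O)(NCCNc1nccc(-c2c(-c3cccc(F)c3)nc3sccn23)n1)c1ccc(F)cc1` sits nearest at 9450 nM, while compound 1 `O=C(NCCNc1nccc(-c2c(-c3cccc(F)c3)nc3sccn23)n1)c1ccc(Cl)cc1` gives 2570 nM. Compound 4 `O=C(NCCNc1nccc(-c2c(-c3cccc(F)c3)nc3sccn23)n1)c1c(F)cccc1F` is not yet measured. The change from compound 3 to compound 4 is (2,6-difluorophenyl)carbonyl in place of (4-chlorophenyl)sulfonyl on an amine nitrogen. Within the data shown here, the steps that bear on it run the other way: a 7.2-fold higher number from compound 1 to compound 3 (0.86 log units; beyond the scatter) and a 3.7-fold higher number from compound 1 to compound 2 (0.57 log units; beyond the scatter), both modest and beyond the scatter. Returning from sulfonyl to carbonyl should therefore lower the number; the shift of fluorine pattern on the ring has no measured counterpart, so the expected step is a 5.3-fold lower number from compound 3 to compound 4 (0.73 log units; beyond the scatter). Compound 4 is estimated at 3500 nM, with a range of 1200 nM to 10000 nM.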

Compound 4, half-maximal inhibitory concentration: 2700 nM
The estimate for compound 4 lay 1.3-fold (0.11 log units) above the measured number; measured number inside the range.
By their numbers in this assay, from the lowest: compounds 1 and 4 (each within the scatter of the next); then compounds 2 and 3 (each within the scatter of the next).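

With a second aryl group on the carbonyl, the gap at this amine nitrogen persists: there is a 6.9-fold lower number from compound 3 to compound 4 (0.84 log units; beyond the scatter) and a 3.5-fold lower number from compound 2 to compound 4 (0.54 log units; beyond the scatter) in this pair of steps, so both sulfonyl compounds sit on the higher side of both carbonyl compounds. Exchanging the aryl group on the carbonyl carbon gives a 1.1-fold higher number from compound 1 to compound 4 (0.02 log units; within the scatter) and does not separate 2,6-difluorophenyl from 4-chlorophenyl. No measurement at hand accounts for the gap between carbonyl and sulfonyl. Open, on these data alone, is whether an acetyl group or a urea would hold the lower numbers, and whether a longer chain would preserve them.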